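Methoxy in Place of Chloro on the Anilide of Compound 3

This account rests on a few compounds, and the source may have more. Where it says the series, first, only, none or still open, it means among the compounds named here.

Compound 3 `O=C(Nc1cccc(Cl)c1)c1cncc(N2CC3CC(C2)N3)c1` gives 0.042 nM in an assay on membranes from Cerebral cortex for displacement of a labelled ligand from Neuronal acetylcholine receptor; alpha4/beta2 (Rattus norvegicus) (a higher number here means a weaker inhibitor, a lower number a stronger inhibitor), the lowest of the three numbers seen so far; compound 2 `O=C(Nc1ccc(Cl)cc1)c1cncc(N2CC3CC(C2)N3)c1` gives 0.404 nM and compound 1 `COc1ccc(NC(=O)c2cncc(N3CC4CC(C3)N4)c2)cc1OC` gives 0.828 nM. Among the compounds with values here, the only single-point step measured, a 9.6-fold lower number from compound 2 to compound 3 (0.98 log units; beyond the scatter), relocated the chloro substituent and lies beyond the scatter. Compound 4 `COc1cccc(NC(=O)c2cncc(N3CC4CC(C3)N4)c2)c1` differs from compound 3 by methoxy in place of chloro on an aromatic carbon, the new group standing meta to a large group. Within the data shown here, no measured pair exchanges chloro for methoxy at a single position, so the bearing is indirect: compound 1, which carries two methoxy groups, sits well above compound 3. Compound 4 is therefore expected to be somewhat weaker, a step of a 2.9-fold higher number from compound 3 to compound 4 (0.46 log units; beyond the scatter), with an estimated value of 0.12 nM (range 0.03 nM to 0.5 nM).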

Compound 4, inhibition constant: 0.56 nM
Compound 4: the middle estimate sits 4.7-fold (0.67 log units) below what was measured; the measured number lies above the stated range.
By their numbers in this assay, from the lowest: compound 3; then compounds 2, 4 and 1 (each within the scatter of the next, the first and the last beyond it).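

In this assay, within the data shown here, the change from 3-chlorophenyl to 3-methoxyphenyl gives the first direct reading at this position, a 13-fold higher number from compound 3 to compound 4 (1.12 log units; beyond the scatter), so the low number of compound 3 is tied to chloro rather than to just any group standing there. With methoxy in place, the anilide no longer sets itself apart from the other two compounds: a 1.4-fold higher number from compound 2 to compound 4 (0.14 log units; within the scatter) and a 1.5-fold lower number from compound 1 to compound 4 (0.17 log units; within the scatter). Nothing available explains the size of the step from chloro to methoxy.

As far as these compounds go, whether fluoro, methyl or a nitrile on the same carbon would keep the low number of compound 3 remains open. So does the effect of an amine or a carboxylic acid there.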